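The compounds below may be only part of what the source reports. "The series", "measured", "known", "first", "only" and "open" are said of these compounds alone.

Compound 1 `CCOc1ccc2c(Cl)ccnc2c1` in a functional assay on SK-OV-3 cells (Homo sapiens) for cytotoxicity, read by MTT assay, with a stated time of 48 h (a higher number here means a weaker inhibitor, a lower number a stronger inhibitor), gives 3460 nM. Compound 2 `CCOc1ccc2c(NCCN(C)C)ccnc2c1` in this assay gives 4620 nM. Of the two numbers, that of compound 1 is the lower, but the step of a 1.3-fold higher number from compound 1 to compound 2 (0.13 log units; within the scatter) stays within the scatter, so no real separation is claimed. Compound 3 `Clc1ccnc2cc(OCc3ccccc3)ccc12` differs from compound 1 by phenyl in place of methyl on a saturated chain carbon bound to an oxygen on an aromatic ring. Among the measured compounds shown here, no measured step touches the saturated chain carbon bound to an oxygen on an aromatic ring; the only known step, a 1.3-fold higher number from compound 1 to compound 2 (0.13 log units; within the scatter), concerns another place and stayed within the scatter. Compound 3 is therefore expected at 3000 nM, within 1000 nM to 9000 nM, a step of a 1.2-fold lower number from compound 1 to compound 3 (0.06 log units; within the scatter) not beyond the scatter.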

Compound 3, half-maximal inhibitory concentration: 5170 nM
For compound 3 the middle estimate is 1.7-fold (0.24 log units) below the measured one, within the range that was stated.
By their numbers in this assay, from the lowest: compounds 1, 2 and 3 (each within the scatter of the next).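

At the saturated chain carbon bound to an oxygen on an aromatic ring, phenyl in place of methyl gives a 1.5-fold higher number from compound 1 to compound 3 (0.17 log units; within the scatter) in this assay. This position therefore tolerates a six-membered aromatic ring of carbon only, with no real separation from methyl in this read-out. Nothing at hand explains the outcome of this change.

Still open, as far as these compounds go, is whether a carboxylic acid or a longer chain at this place would separate from methyl. Also open, from the compounds shown here alone, is how phenyl here would combine with (2-(dimethylamino)ethyl)amino in place of chloro.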